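Working notes: swapping the aryl group on compound 1

The source may report more compounds than this note shows. Statements on the series, on what has been measured and on what is new or still open speak of the compounds shown alone.

compound 1 `COc1ccccc1NC(=S)N/N=C/c1ccc2ccccc2n1`: 91700 nM
compound 2 `NC(=S)N/N=C/c1cc2cccnc2s1`: > 100000 nM (a limit)
compound 3 `NC(=S)N/N=C/c1nc2ccccc2s1`: > 100000 nM (a limit)

Among the measured compounds shown here, in a functional assay on HL-60 cells (Homo sapiens) for antiproliferative activity, read by sulforhodamine B assay, with a stated time of 72 h (on this read-out higher numbers stand for weaker inhibition and lower numbers for stronger inhibition), compound 1 gives 91700 nM, the only actual number in the set. Compound 2 stands at > 100000 nM, which is a limit and not a number. Compound 3 stands at > 100000 nM, again a limit.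

Compound 4 `Cc1ccc(NC(=S)N/N=C/c2ccc3ccccc3n2)cc1` keeps the core of compound 1 and carries 4-methylphenyl in place of 2-methoxyphenyl on an amide-type nitrogen. For the measured compounds named here, no step between measured compounds is available to calibrate this change in this assay, so any expectation is loose. A moderate step towards stronger inhibition is expected, since compound 1 at 91700 nM already shows only weak inhibition, and a still weaker result would probably not be reported as a number. The expected change is a 2.0-fold lower number from compound 1 to compound 4 (0.31 log units; beyond the scatter), an estimate only. For compound 4 the estimated value is 45000 nM, with an expected range of 6000 nM to 100000 nM.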

Compound 4, half-maximal inhibitory concentration: 78300 nM
The estimate for compound 4 lay 1.7-fold (0.24 log units) below the measured number; measured number inside the range.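

In this assay, among the compounds shown here, 4-methylphenyl in place of 2-methoxyphenyl on an amide-type nitrogen gives a 1.2-fold lower number from compound 1 to compound 4 (0.07 log units; within the scatter), the first step that can be read. For this pair, the aryl group at this place can be exchanged, and the hydrogen-bond acceptor of 2-methoxyphenyl removed, without a change beyond the scatter. Any further weakening from this pair could be followed only over a short span, because readings in this series stop at a limit, which is not a number: the limit of > 100000 nM in this assay, at which 2 of the 4 values shown sit.

For the compounds shown here, compound 2 and compound 3 differ from the others in more than one place, so no steps to them can be read. Open, as far as these compounds go, is whether a basic amine such as a dimethylaminophenyl group, or a carboxylic acid on the phenyl ring, would move the number at this nitrogen.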